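The source may hold more compounds than are shown below. What is called first, only, known or untested is meant among the compounds shown, and "the series" means these compounds.

Measured compounds:
compound 1, `Cc1nc(-c2nc3ccccc3[nH]2)c(N2CCN(C(=O)Cn3cnc4cccnc43)[C@H](C)C2)s1`, giving 9 nM
compound 2, `CCOc1ncc(-c2nc(C(F)(F)F)sc2N2CCN(C(=O)Cn3ccc4cnccc43)[C@H](C)C2)cn1`, giving 3.6 nM
compound 3, `Cc1nc(C)n(CC(=O)N2CCN(c3sc(C(F)(F)F)nc3-c3cnc(OC4CCC4)nc3)C[C@H]2C)n1`, giving 4 nM

All three were tested in a functional assay on CHO-K1 cells for antagonist activity at C-X-C chemokine receptor type 3 (Homo sapiens), read by FLIPR, with a stated time of 10 min; on this read-out lower numbers stand for stronger inhibition and higher numbers for weaker inhibition. Compound 3 has the second highest of the three numbers. Its nearest neighbour is compound 2, whose value in this assay is 3.6 nM, a gap within the usual scatter, so the two cannot be told apart. The furthest is compound 1, whose 9 nM is a gap beyond the scatter, so compound 1 is the weaker of that pair.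

Compound 4, `COc1ccc(-c2nc(C(F)(F)F)sc2N2CCN(C(=O)Cn3nc(C)nc3C)[C@H](C)C2)cn1`, has not yet been measured. Within the data shown here, its one change from compound 3 is 6-methoxypyridin-3-yl in place of 2-(cyclobutyloxy)pyrimidin-5-yl on an aromatic carbon. The acetamide part and the rest of the shared core stay as in compound 3. Among the measured compounds shown here, no pair of measured compounds shows the effect of this particular swap, so the expectation rests on the three values alone, which all sit close together despite different groups at that carbon.

The step from compound 3 to compound 4 is therefore expected to be a 1.5-fold higher number from compound 3 to compound 4 (0.18 log units; within the scatter), small and not clearly beyond the scatter. Compound 4 is estimated at 6 nM, within 2 nM to 20 nM.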

Compound 4, half-maximal inhibitory concentration: 18 nM
Compound 4: the middle estimate sits 3.0-fold (0.48 log units) below what was measured; the measured number falls inside the stated range.
By their numbers in this assay, from the lowest: compounds 2 and 3 (each within the scatter of the next); then compounds 1 and 4 (each within the scatter of the next).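

Swapping 2-(cyclobutyloxy)pyrimidin-5-yl for 6-methoxypyridin-3-yl on this aromatic carbon gives a 4.5-fold higher number from compound 3 to compound 4 (0.65 log units; beyond the scatter) in this assay, the first single-place comparison showing that the number responds to the group here. The earlier compounds shown here differ in several places at once, so their close values could not show this. The change removes the four-membered carbon ring and one ring nitrogen together, and nothing measured here gives a reason for the step.

As far as these compounds go, it remains open which part of the change matters, and 6-(cyclobutyloxy)pyridin-3-yl or 2-methoxypyrimidin-5-yl at this carbon would separate the ring from the ether group. Also open, from the compounds shown here alone, is how an amine or a carboxylic acid on that six-membered ring would compare.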